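From compound 2 to compound 3: a 3-fluorobenzyl group

A few compounds are considered here, and "the series" means these few. Any claim that something is new, unique, unknown or untested is made for them only; others in the source may bear on it.

Compounds in a functional assay on RAW264.7 cells (Mus musculus) for inhibition, read by immunoassay, with a stated time of 12 h; a lower number here means a stronger inhibitor, a higher number a weaker inhibitor:
- Compound 1 `O=C1CC(c2ccccc2OCc2ccccc2)Oc2ccccc21`: 25200 nM
- Compound 2 `O=C1CC(c2ccccc2O)Oc2ccccc21`: 71300 nM
- Compound 3 `O=C1CC(c2ccccc2OCc2cccc(F)c2)Oc2ccccc21`: not yet measured

Of the two compounds measured in this assay, compound 2 gives the higher number, 71300 nM, and is therefore the weaker inhibitor of the pair. The next value is that of compound 1, at 25200 nM.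

The change now in question is 3-fluorobenzyl in place of hydrogen on an oxygen on an aromatic ring. In words, it places 3-fluorobenzyl in place of hydrogen on an oxygen on an aromatic ring. For the measured compounds named here, only one measured step bears on this change: a 2.8-fold higher number from compound 1 to compound 2 (0.45 log units; beyond the scatter), with hydrogen in place of benzyl on that oxygen. Compound 3 carries 3-fluorobenzyl where compound 1 carries benzyl, so a modest step of similar size, toward a lower number, is expected in this assay. Going by the values given here, no measured compound shows what the fluorine adds, so the expectation rests on this single step and stays uncertain. The expected step is a 3.1-fold lower number from compound 2 to compound 3 (0.49 log units; beyond the scatter). For compound 3 the estimated value is 23000 nM, with an expected range of 9000 nM to 60000 nM.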

Compound 3, half-maximal inhibitory concentration: 27400 nM
Estimate against measurement, compound 3: 1.2-fold (0.08 log units) below; low and high end bracket the measured number.
By their numbers in this assay, from the lowest: compounds 1 and 3 (each within the scatter of the next); then compound 2.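

In this assay, 3-fluorobenzyl in place of hydrogen on an oxygen on an aromatic ring gives a 2.6-fold lower number from compound 2 to compound 3 (0.42 log units; beyond the scatter), so the drop seen with benzyl at this oxygen now appears with a second group of the same kind, and in both compounds 1 and 3 the number is lower than with hydrogen there. Fluoro in place of hydrogen on an aromatic carbon gives a 1.1-fold higher number from compound 1 to compound 3 (0.04 log units; within the scatter), so compounds 1 and 3 cannot be told apart in this assay, and the added fluorine, at this one place on the benzyl ring, leaves no measurable mark on the number. Nothing available accounts for either step.

The compounds shown leave open whether the aromatic ring of the benzyl group is needed at all, since a plain methyl or a longer chain on this oxygen does not appear among them. They also leave open whether a chloro, a methoxy, an amine or a carboxylic acid on the benzyl ring would move the number where fluoro did not.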